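This account rests on a few compounds, and the source may have more. Where it says the series, first, only, none or still open, it means among the compounds named here.

Measured compounds:
compound 1, `CC(C(=O)NCc1ccc(C(F)(F)F)nc1N(C)C)c1ccc(NS(C)(=O)=O)c(F)c1`: 2390 nM
compound 2, `C[C@@H](C(=O)NCc1ccc(C(F)(F)F)nc1N1CCC(c2ccccc2)CC1)c1ccc(NS(C)(=O)=O)c(F)c1`: 2350 nM

In a functional assay on CHO-K1 cells for antagonist activity at transient receptor potential cation channel subfamily V member 1 (Homo sapiens), read by FLIPR (a higher number here means a weaker inhibitor, a lower number a stronger inhibitor), compound 1 gives 2390 nM, and compound 2 gives 2350 nM; the two numbers lie within the usual scatter of each other, so compound 1 stands level with compound 2 on the numbers shown. Compound 3, `CC(C(=O)NCc1ccc(C(F)(F)F)nc1N1CCC(C(F)(F)F)CC1)c1ccc(NS(C)(=O)=O)c(F)c1`, has not yet been measured. It differs from compound 1 by 4-(trifluoromethyl)piperidin-1-yl in place of dimethylamino on an aromatic carbon. Within the data shown here, no step between two measured compounds informs this change directly. The step from compound 1 to compound 3 is therefore expected to be a 1.3-fold lower number from compound 1 to compound 3 (0.12 log units; within the scatter), nothing beyond the scatter. Compound 3 is estimated at 1800 nM, within 500 nM to 6000 nM.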

Compound 3, half-maximal inhibitory concentration: 31 nM
Compound 3: the middle estimate sits 58-fold (1.76 log units) above what was measured; measured number below the stated range.
By their numbers in this assay, from the lowest: compound 3; then compounds 2 and 1 (each within the scatter of the next).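

In this assay, 4-(trifluoromethyl)piperidin-1-yl in place of dimethylamino on the aromatic carbon next to the ring nitrogen gives a 77-fold lower number from compound 1 to compound 3 (1.89 log units; beyond the scatter) and so shows that this position can strongly change the inhibition read-out. Compounds 1 and 2 differ in more than one place and could not show this for a single change. Nothing available here accounts for the size of this step. The compounds shown leave open whether the piperidine ring or its trifluoromethyl group carries the step. An unsubstituted piperidin-1-yl or a morpholin-4-yl at this position would help separate the two.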